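The compounds below may be only part of what the source reports. "The series", "measured", "known", "first", "only" and "open" are said of these compounds alone.

Compound 1 `CCCCCNc1cc(Oc2c(OC)cc3cc(C#N)ccc3c2OC)nc(Nc2ccc(C#N)cc2)n1`, compound 2 `COc1cc2cc(C#N)ccc2c(OC)c1Oc1cc(NC(C)C)nc(Nc2ccc(C#N)cc2)n1` and compound 3 `CCCC(CCC)Nc1cc(Oc2c(OC)cc3cc(C#N)ccc3c2OC)nc(Nc2ccc(C#N)cc2)n1` share one core and differ only in the group carried on a nitrogen on an aromatic ring. In an ADME assay on MT4 cells (Homo sapiens) for cytotoxicity, read by MTT assay, with a stated time of 5 days (on this read-out lower numbers stand for higher toxicity in this test and higher numbers for lower toxicity in this test), compound 1 gives > 125000 nM, which is a limit of the assay rather than a number. Compound 2 gives > 125000 nM, likewise a limit. Compound 3 gives > 125000 nM, again a limit. The steps a step that the two limits leave unreadable from compound 1 to compound 2, a step that the two limits leave unreadable from compound 1 to compound 3 and a step that the two limits leave unreadable from compound 2 to compound 3 therefore cannot be sized, since (the limit of > 125000 nM in this assay, at which 3 of the 3 values shown sit). Compound 4 `COc1cc2cc(C#N)ccc2c(OC)c1Oc1cc(NC2CCOC2)nc(Nc2ccc(C#N)cc2)n1` differs from compound 3 by oxolan-3-yl in place of 1-propylbutyl on a nitrogen on an aromatic ring. No measured step can be read, so no change beyond the scatter is expected from this replacement. In this assay compound 4 is expected to give 125000 nM, between 60000 nM and 200000 nM. The expected step is a number no higher from compound 3 to compound 4 (the limit leaves the size open).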

Compound 4, half-maximal cytotoxic concentration: > 125000 nM
Compound 4 ended at the assay's limit (the forecaster's own chance of this, stated with the estimate: 85%); the middle value sits exactly at the limit.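

Compound 4 sits at the same limit as compound 1, compound 2 and compound 3, so none of its steps to them can be read: the limit of > 125000 nM in this assay, at which 4 of the 4 values shown sit.

As far as these compounds go, at what concentration any of these four compounds would become toxic in this assay stays open, and so does whether the group on the nitrogen matters there at all.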